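The compounds below may be only part of what the source reports. "The series", "measured", "known", "first", "only" and "open" are said of these compounds alone.

In a functional assay on SK-OV-3 cells (Homo sapiens) for inhibition, read by MTT assay (on this read-out higher numbers stand for weaker inhibition and lower numbers for stronger inhibition), compound 1 `COc1ccc(/C=C2\c3cc(OC)c(OC)c(OC)c3CC[C@@H]2O)cc1C#N` gives 20 nM and compound 3 `COc1ccc(/C=C2\c3cc(OC)c(OC)c(OC)c3CC[C@@H]2O)cc1[N+](=O)[O-]` gives 4640 nM while compound 2 `COc1ccc(/C=C2\c3cc(OC)c(OC)c(OC)c3CC[C@@H]2O)cc1N` gives 740 nM as the middle number. The change to compound 4 `COc1ccc(/C=C2\c3cc(OC)c(OC)c(OC)c3CC[C@H]2O)cc1N` is one of configuration alone: the two compounds have the same atoms and bonds and differ only in configuration as drawn: 1 of 2 stereo elements differ; a stereocentre at a saturated ring carbon is drawn S in compound 2 and R in compound 4 with no atom gained or lost. Going by the values given here, the measured steps of a 37-fold higher number from compound 1 to compound 2 (1.57 log units; beyond the scatter) and a 230-fold higher number from compound 1 to compound 3 (2.37 log units; beyond the scatter) and a 6.3-fold higher number from compound 2 to compound 3 (0.80 log units; beyond the scatter) all swap aromatic substituents and range from large to modest, yet none touches this stereocentre and no pair differing only in configuration has been measured. Direction therefore stays open, and no shift beyond the scatter is the central expectation, though a larger one cannot be excluded. The expected step is a 1.2-fold higher number from compound 2 to compound 4 (0.09 log units; within the scatter) on this estimate. Compound 4 is estimated at 900 nM with an expected range from 200 nM to 4000 nM as a deliberately wide band.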

Compound 4, half-maximal inhibitory concentration: 1870 nM
For compound 4 the middle estimate is 2.1-fold (0.32 log units) below the measured one; the range from low to high includes it.
By their numbers in this assay, from the lowest: compound 1; then compound 2; then compound 4; then compound 3.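

In this assay, the stereocentre at a saturated ring carbon now gives its first reading, a 2.5-fold higher number from compound 2 to compound 4 (0.40 log units; beyond the scatter). All earlier steps swapped aromatic substituents, and this one is smaller than a 37-fold higher number from compound 1 to compound 2 (1.57 log units; beyond the scatter), yet configuration alone still moves the number beyond the scatter, and the shift can be assigned to this stereocentre because nothing else changes: the fact that compounds 2 and 4 differ only in the configuration as drawn

Going by these compounds, whether the same configurational change gives a step of similar size and direction with the cyano group of compound 1 or the nitro group of compound 3 stays open. Also open, on these data alone, is how an acetamide or a carboxylic acid in place of the amino group would behave in either configuration.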